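The source may hold more compounds than are shown below. What is called first, only, known or untested is meant among the compounds shown, and "the series" means these compounds.

Working notes on the series. Compound 1 `c1ccc(C(/N=C2\CCCCN2)c2ccco2)cc1` and compound 3 `c1ccc(C(/N=C2\CCCCN2)c2cccs2)cc1` share one core; compound 2 `c1ccc(C(/N=C2\CCCCCCN2)c2ccco2)cc1` and compound 4 `c1ccc(C(/N=C2\CCCCCCN2)c2cccs2)cc1` share another, and the difference between the two cores is not broken down here. In a functional assay on the whole organism (plasma, strain Sprague-Dawley) with Rattus norvegicus as the target, with a stated time of 2 h, at a dose of 12.5 mg/kg by the oral route (on this read-out lower numbers stand for a weaker effect and higher numbers for a stronger effect at the one dose given), compound 1 gives 13%, compound 2 gives 22% and compound 3 gives 13%. The change from compound 1 to compound 3 is thiophen-2-yl in place of furan-2-yl on a saturated chain carbon bound to an aromatic carbon and a double-bonded nitrogen, and the read-out does not move with it: no change at the digits printed from compound 1 to compound 3 (within the scatter). The change from compound 2 to compound 4 is thiophen-2-yl in place of furan-2-yl on a saturated chain carbon bound to an aromatic carbon and a double-bonded nitrogen, the same change at the same place. Compound 4 has no value yet in this assay. For the measured compounds named here, the step from compound 2 to compound 4 is expected to be no change at the digits printed from compound 2 to compound 4 (within the scatter), resting on the single measured instance of this change, no change at the digits printed from compound 1 to compound 3 (within the scatter). Compound 4 is therefore estimated at 22% in this assay, within a range from 8% to 36%.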

Compound 4, a percentage reported as inhibition, in the whole organism at one dose (the size of the read-out at that dose, not a potency): 29%
Compound 4: middle estimate off by 7 percentage points, on the low side; measured number inside the range.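

In this assay, thiophen-2-yl in place of furan-2-yl gives a number 7 percentage points higher from compound 2 to compound 4 (within the scatter), and the step carries from one core to the other without a difference beyond the scatter: the same change on two cores in this assay, no change at the digits printed (within the scatter) from compound 1 to compound 3 and a number 7 percentage points higher (within the scatter) from compound 2 to compound 4, 7 percentage points apart, within the scatter of two such steps

This agreement rests on two pairs of compounds at one dose and one time. It does not show that the change has any effect on this read-out, and it does not show that the agreement would hold on a third core.

Still open, on these data alone, is how a group of another kind, such as an amine or a carboxylic acid, would read in place of furan-2-yl on that saturated chain carbon. Also open, as far as these compounds go, is whether a longer chain on that carbon would leave the read-out as it stands.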